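The source may hold more compounds than are shown below. What is called first, only, known or untested is meant among the compounds shown, and "the series" means these compounds.

Within the data shown here, in a toxicity assay on microsomes from liver (Homo sapiens) for metabolic stability, read by LC-MS, using NADPH, tested at 1 uM (a lower number here means slower removal, a higher number faster removal of the compound), compound 2 (`CCCc1ncc(-c2nc(C(F)(F)F)sc2N2CCN(C(=O)Cn3nc(C)nc3C)[C@H](C)C2)cn1`) gives 80 mL.min-1.g-1, the only exact number available so far. Compound 1 (`COc1ncc(-c2nc(C(F)(F)F)sc2N2CCN(C(=O)Cn3nc(C)nc3C)[C@H](C)C2)cn1`) shares its core and differs at one place. Compound 1 gives < 10 mL.min-1.g-1, which is a limit and not a number.

Among the measured compounds shown here, the one measured step is an at least 8.0-fold higher number from compound 1 to compound 2 (0.90 log units; beyond the scatter), with propyl in place of methoxy on an aromatic carbon, and its size is only a bound because of the limit of < 10 mL.min-1.g-1 in this assay, at which 1 of the 2 values shown sits.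

Compound 3 (`Cc1nc(C)n(CC(=O)N2CCN(c3sc(C(F)(F)F)nc3-c3cnc(C(C)(C)C)nc3)C[C@H]2C)n1`) changes the same place, with tert-butyl in place of propyl on an aromatic carbon. The step to compound 2 shows that a change at this place can matter, as an at least 8.0-fold higher number from compound 1 to compound 2 (0.90 log units; beyond the scatter) makes clear, but it involved methoxy. Here, one carbon-only group replaces another, with no hydrogen-bond donor or acceptor on either side. A step of that size is therefore not expected, and none beyond the scatter is the likeliest outcome, with a slight lean towards a lower number. The expected step is a 1.6-fold lower number from compound 2 to compound 3 (0.20 log units; within the scatter). For compound 3, the estimated value is 50 mL.min-1.g-1, with an expected range of 20 mL.min-1.g-1 to 110 mL.min-1.g-1.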

Compound 3, intrinsic clearance in microsomes: 449 mL.min-1.g-1
Estimate against measurement, compound 3: 9.0-fold (0.95 log units) below; the whole stated range lies below it.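

In this assay, tert-butyl in place of propyl gives a 5.6-fold higher number from compound 2 to compound 3 (0.75 log units; beyond the scatter) and so shows that this place, between two ring nitrogen atoms, responds beyond the scatter even when one carbon-only group replaces another, with no hydrogen-bond donor or acceptor on either side. The earlier step could not show this, as it involved methoxy, whereas the full change from methoxy to tert-butyl gives an at least 44-fold higher number from compound 1 to compound 3 (1.65 log units; beyond the scatter) and makes the three groups a rising series in this assay, with propyl in the middle. The size of that full change is only a bound because compound 1 gives a limit and not a number: the limit of < 10 mL.min-1.g-1 in this assay, at which 1 of the 3 values shown sits.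

The compounds shown do not separate the carbon count of the group from its branching, a question that a straight butyl chain or a cyclopropyl group at this place would address. They also leave open how the number would respond to a methoxyethyl chain or an amine here, groups that would put a heteroatom back at this place while keeping a larger group than methoxy.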